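The source may hold more compounds than are shown below. What is called first, only, known or untested is meant among the compounds shown, and "the series" means these compounds.

Compound 2 `NCC(=O)NS(=O)(=O)c1ccc(Nc2nc(N)n(C(=O)c3c(F)cccc3F)n2)cc1` is one of two analogues that share a core and differ only at the saturated chain carbon bound to the carbonyl carbon of the acyl sulfonamide. In an ADME assay on the whole organism for metabolic stability, with Rattus norvegicus as the target (a lower number here means that the compound disappears faster, a higher number that the compound lasts longer), compound 2 gives 0.16 h. Going by the values given here, its only measured neighbour is compound 1 `Nc1nc(Nc2ccc(S(=O)(=O)NC(=O)CCC(=O)O)cc2)nn1C(=O)c1c(F)cccc1F`, which in this assay gives 0.16 h; the step of no change at the digits printed from compound 1 to compound 2 (within the scatter) shows that exchanging carboxymethyl for amino at this position left the half-life where it was.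

Compound 3 `COCCOCC(=O)NS(=O)(=O)c1ccc(Nc2nc(N)n(C(=O)c3c(F)cccc3F)n2)cc1` has not yet been measured. It differs from compound 2 in the change (2-methoxyethoxy in place of amino on a saturated chain carbon bound to a carbonyl carbon). Among the compounds with values here, the one step that bears on this site, no change at the digits printed from compound 1 to compound 2 (within the scatter), was flat, so a polar group of a different kind at the same carbon did not move the read-out. On that basis compound 3 is expected to sit close to compound 2, with the step of no change at the digits printed from compound 2 to compound 3 (within the scatter) expected to stay within the scatter. The estimate for compound 3 in this assay is therefore 0.16 h, with a plausible range from 0.08 h to 0.4 h, pending the actual measurement.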

Compound 3, half-life in the Rattus norvegicus assay: 0.16 h
The estimate for compound 3 equals the measured number at the digits printed, and the stated range covers the measured number.
By their numbers in the Rattus norvegicus assay, from the lowest: compounds 1, 2 and 3 (each within the scatter of the next).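

In the Rattus norvegicus assay the record now reads no change at the digits printed from compound 2 to compound 3 (within the scatter) and no change at the digits printed from compound 1 to compound 3 (within the scatter) and so this carbon has carried amino, carboxymethyl and 2-methoxyethoxy with no step beyond the scatter. Going by these compounds alone, the exchange of amino for 2-methoxyethoxy is not silent everywhere, however: in a physicochemical assay for solubility, at pH 2.0 (a higher number here means a more soluble compound, a lower number a less soluble compound), the record reads a 24-fold lower number from compound 2 to compound 3 (1.38 log units; beyond the scatter) and this is the first sign that the position matters at all. In the physicochemical assay compound 2 gives 130 ug/mL and compound 3 gives 5.4 ug/mL. Half-life and solubility thus part at this site, and the longer ether chain costs solubility at the printed half-life: the measured solubility of compound 2, 130 ug/mL, and of compound 3, 5.4 ug/mL, a 24-fold lower number (1.38 log units; beyond the scatter).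

The compounds shown leave open whether any group on this saturated chain carbon can move the half-life, or whether the shared core alone holds it at this level, and a tertiary amine, a morpholine ring or a longer carboxylic acid chain would put that to the test. They also leave open whether the solubility of compound 2 depends on the amine itself, which a hydroxyl group or a methylamino group in the same place could separate from the effect of chain length.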